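Amine substitution on the shared core: toward compound 4

The source may report more compounds than this note shows. Statements on the series, on what has been measured and on what is new or still open speak of the compounds shown alone.

Measured in a functional assay on HCT-116 cells (Homo sapiens) for inhibition; on this read-out higher numbers stand for weaker inhibition and lower numbers for stronger inhibition:
compound 1, `CCNC(=O)c1noc(-c2cc(C(C)C)c(O)cc2O)c1-c1cc(CNC)no1`: 164 nM
compound 2, `C=CNCc1cc(-c2c(C(=O)NCC)noc2-c2cc(C(C)C)c(O)cc2O)on1`: 121 nM
compound 3, `CCNC(=O)c1noc(-c2cc(C(C)C)c(O)cc2O)c1-c1cc(CNC(C)=O)no1`: 167 nM

Compound 1 stands second highest of these three numbers; compound 3 is nearest and compound 2 furthest, and every step among them lies within the scatter: a 1.0-fold higher number from compound 1 to compound 3 (0.01 log units; within the scatter), a 1.4-fold lower number from compound 1 to compound 2 (0.13 log units; within the scatter), a 1.4-fold higher number from compound 2 to compound 3 (0.14 log units; within the scatter). Compound 4 `CCNC(=O)c1noc(-c2cc(C(C)C)c(O)cc2O)c1-c1cc(CN2CCN(C)CC2)no1` differs from compound 1 in one place: 4-methylpiperazin-1-yl in place of methylamino on a saturated chain carbon bound to an aromatic carbon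

Among the measured compounds shown here, the measured steps all vary the group on this amine nitrogen (vinyl or acetyl in place of methyl) and none moved the number beyond the scatter; no measured step brings in a ring, so that part of the change has no precedent here. Compound 4 is therefore expected to give about 160 nM in this assay, within 70 nM to 400 nM. The expected step of a 1.0-fold lower number from compound 1 to compound 4 (0.01 log units; within the scatter) is estimated to stay within the scatter.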

Compound 4, half-maximal inhibitory concentration: 340 nM
Beside the measured number, compound 4's estimate is 2.1-fold (0.33 log units) below it; the range from low to high includes it.
By their numbers in this assay, from the lowest: compounds 2, 1 and 3 (each within the scatter of the next); then compound 4.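

In this assay, among the compounds shown here, the saturated chain carbon bound to an aromatic carbon is not indifferent to the amine it carries: 4-methylpiperazin-1-yl gives the only steps here beyond the scatter, a 2.1-fold higher number from compound 1 to compound 4 (0.32 log units; beyond the scatter), a 2.0-fold higher number from compound 3 to compound 4 (0.31 log units; beyond the scatter) and a 2.8-fold higher number from compound 2 to compound 4 (0.45 log units; beyond the scatter). All three are modest, while the three groups without a ring stay within the scatter of one another, so only the group with the ring stands apart. Nothing available accounts for this shift. Going by these compounds, whether the step follows the ring or its second nitrogen stays open. Piperidine, morpholine or unsubstituted piperazine in the same place would separate the two.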